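Chain-end variation in a sulfonyl series

The source may report more compounds than this note shows. Statements on the series, on what has been measured and on what is new or still open speak of the compounds shown alone.

Measured compounds in a functional assay, read by fluorescence and spectrophotometry, with a stated time of 1 h; a lower number here means that less compound is needed, a higher number that more compound is needed for the effect:
compound 1 `C=CCCCCCCS(=O)(=O)/C=C/c1ccc(O)c(O)c1` gives 6400 nM
compound 2 `CCCCCS(=O)(=O)/C=C/c1ccc(O)c(O)c1` gives 8100 nM
compound 3 `O=S(=O)(/C=C/c1ccc(O)c(O)c1)CCCCCCCO` gives 5900 nM

Compound 1 stands second highest of the three numbers. Its nearest neighbour is compound 3 and its furthest is compound 2, and both gaps sit within the scatter. The measured steps are a 1.3-fold higher number from compound 1 to compound 2 (0.10 log units; within the scatter), a 1.1-fold lower number from compound 1 to compound 3 (0.04 log units; within the scatter) and a 1.4-fold lower number from compound 2 to compound 3 (0.14 log units; within the scatter); each of them alters the far end of the saturated chain on the sulfonyl sulfur and none leaves the scatter.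

Compound 4 `O=S(=O)(/C=C/c1ccc(O)c(O)c1)CCCC1CCCCC1` has not been measured. It differs from compound 1 as follows: cyclohexyl in place of pent-4-en-1-yl on a saturated chain carbon, three bonds along the chain from a sulfonyl sulfur. All three measured steps bear on it in that they also rework the chain attached to the sulfonyl sulfur, and all three were flat. On that basis no step beyond the scatter is expected in this assay, in either direction, which is expressed as a 1.2-fold lower number from compound 1 to compound 4 (0.07 log units; within the scatter). Compound 4 is therefore estimated at 5500 nM, with a range from 2500 nM to 12000 nM.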

Compound 4, half-maximal effective concentration: 7900 nM
Beside the measured number, compound 4's estimate is 1.4-fold (0.16 log units) below it; low and high end bracket the measured number.
By their numbers in this assay, from the lowest: compounds 3, 1, 4 and 2 (each within the scatter of the next).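

In this assay, going by these compounds alone, a ring now stands on the chain for the first time, closer to the sulfonyl sulfur than the earlier changes, and cyclohexyl in place of pent-4-en-1-yl gives a 1.2-fold higher number from compound 1 to compound 4 (0.09 log units; within the scatter) at this position. Within the data shown here, measured against the other two chain ends, cyclohexyl in place of 4-hydroxybutyl gives a 1.3-fold higher number from compound 3 to compound 4 (0.13 log units; within the scatter) and cyclohexyl in place of ethyl gives a 1.0-fold lower number from compound 2 to compound 4 (0.01 log units; within the scatter) in the same reading, so every step among compound 1, compound 2, compound 3 and compound 4 stays within the scatter, with no compound going against this. No measurement on hand accounts for this flatness.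

From the compounds shown here alone, whether a chain end carrying an amine or a carboxylic acid would leave the scatter remains open. The same holds for a phenyl ring at this position and for a much longer chain.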